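Swapping methoxy for methyl on a low-activity lactone

A few compounds are considered here, and "the series" means these few. Any claim that something is new, unique, unknown or untested is made for them only; others in the source may bear on it.

Compound 1 `C=C1C(=O)O[C@H](c2ccccc2)[C@H]1c1ccccc1` and compound 2 `C=C1C(=O)O[C@H](c2ccc(OC)cc2)[C@H]1c1ccccc1` share one core. In a functional assay on BXPC-3 cells (Homo sapiens) for cytotoxicity, read by MTT assay, with a stated time of 72 h, tested at 10 uM (on this read-out lower numbers stand for a stronger effect and higher numbers for a weaker effect at the one concentration tested), compound 1 gives 1%, and compound 2 gives 0%; the step of a number 1 percentage points lower from compound 1 to compound 2 (within the scatter) shows no effect beyond the scatter. Compound 2 therefore stands alongside compound 1 at the bottom of the two numbers. Compound 3 `C=C1C(=O)O[C@H](c2ccc(C)cc2)[C@H]1c1ccccc1` arises through (methyl in place of methoxy on an aromatic carbon). Within the data shown here, the one measured step, adding a group at this position, left the read-out unchanged, so no step beyond the scatter is expected here either. For compound 3 the expected value in this assay is 2% (range 0% to 12%), a step of a number 2 percentage points higher from compound 2 to compound 3 (within the scatter).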

Compound 3, a percentage reported as activity, at one concentration (the size of the read-out at that concentration, not a potency): 0%
The estimate for compound 3 lay 2 percentage points above the measured number; low and high end bracket the measured number.
By their numbers in this assay, from the lowest: compounds 2, 3 and 1 (each within the scatter of the next).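

In this assay, methyl in place of methoxy gives no change at the digits printed from compound 2 to compound 3 (within the scatter) and methyl in place of hydrogen gives a number 1 percentage points lower from compound 1 to compound 3 (within the scatter) at this same place on the aromatic ring. Hydrogen, methoxy and methyl at this place therefore all read alike, so a group without the oxygen and its hydrogen-bond acceptor fits in with the other two. Nothing available explains why these three compounds read alike. Still open, as far as these compounds go, is whether an amine, a carboxylic acid or a longer chain at this place would move the number beyond the scatter.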